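This account rests on a few compounds, and the source may have more. Where it says the series, first, only, none or still open, it means among the compounds named here.

Compound 1 `COc1ccc2nc(-c3ccc(N/C=C\C(=O)c4cc(OC)c(OC)c(OC)c4)c(C)c3)sc2c1`: 17000 nM
Compound 2 `COc1ccc2nc(-c3ccc(N/C=C\C(=O)c4cc(OC)c(OC)c(OC)c4Br)c(C)c3)sc2c1`: 9400 nM

In a functional assay on MDA-MB-231 cells (Homo sapiens) for antiproliferative activity, read by sulforhodamine B assay, with a stated time of 48 h (a higher number here means a weaker inhibitor, a lower number a stronger inhibitor), compound 1 gives 17000 nM. Within the data shown here, this lies within the scatter of compound 2, the only other measured compound, at 9400 nM. Compound 3 `COc1ccc2nc(-c3ccc(N/C=C\C(=O)c4cc(OC)c(OC)c([N+](=O)[O-])c4)c(C)c3)sc2c1` is still unmeasured. It departs from compound 1 by nitro in place of methoxy on an aromatic carbon, ortho to a methoxy group: nitro in place of methoxy on an aromatic carbon. Among the measured compounds shown here, the only measured step, a 1.8-fold lower number from compound 1 to compound 2 (0.26 log units; within the scatter), comes with bromo in place of hydrogen on an aromatic carbon. For the measured compounds named here, that is a different change, so it offers only indirect guidance, and no measured compound carries a nitro group. On that slim basis, no step beyond the scatter is expected in this assay, and no direction can be firmly assigned. The expected change is a 1.5-fold lower number from compound 1 to compound 3 (0.19 log units; within the scatter). For compound 3 the estimated value is 11000 nM, with an expected range of 3500 nM to 35000 nM.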

Compound 3, half-maximal inhibitory concentration: 5050 nM
Compound 3: middle estimate off by 2.2-fold (0.34 log units), on the high side, and the stated range covers the measured number.
By their numbers in this assay, from the lowest: compounds 3, 2 and 1 (each within the scatter of the next, the first and the last beyond it).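

In this assay, nitro in place of methoxy on this aromatic carbon, ortho to a methoxy group, gives a 3.4-fold lower number from compound 1 to compound 3 (0.53 log units; beyond the scatter), a modest step. The only earlier step, a 1.8-fold lower number from compound 1 to compound 2 (0.26 log units; within the scatter), came with bromo in place of hydrogen and stayed within the scatter, so this is the first single change shown here to move the number beyond it. Nothing measured here explains the step.

The compounds shown leave open whether this step is specific to nitro, since an amine, a nitrile or a trifluoromethyl group at the same position would show whether other replacements of the methoxy group do the same. They also leave open whether removing the methoxy group and leaving hydrogen there would move the number at all.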